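Rearranging the Piperidine Ether of Compound 2

A few compounds are considered here, and "the series" means these few. Any claim that something is new, unique, unknown or untested is made for them only; others in the source may bear on it.

Compound 1 `Clc1ccc(Oc2ccc3nc(-c4ccc(OC5CCNCC5)cc4)oc3c2)cc1`: 20.6% in an assay on isolated protein for inhibition of advanced glycosylation end product-specific receptor (Homo sapiens), read by FRET, with stated times of 30 min and 1 h, tested at 4 uM; a higher number here means more inhibition at the concentration tested (going by the name of the read-out), a lower number less inhibition
Compound 2 `CC(C)N1CCC(Oc2ccc(-c3nc4ccc(Oc5ccc(Cl)cc5)cc4o3)cc2)CC1`: 12.7%

Going by the values given here, of these two numbers, the one for compound 2 is the smaller, yet the only measured step, a number 7.9 percentage points lower from compound 1 to compound 2 (within the scatter), lies within the scatter, so the two are not really told apart. Compound 3 `CCN1CCC(COc2ccc(-c3nc4ccc(Oc5ccc(Cl)cc5)cc4o3)cc2)CC1` differs from compound 2 by (1-ethylpiperidin-4-yl)methyl in place of 1-isopropylpiperidin-4-yl on an oxygen on an aromatic ring. Among the compounds with values here, no measured step matches this rearrangement; the one known step, a number 7.9 percentage points lower from compound 1 to compound 2 (within the scatter), changed only the group on the ring nitrogen and moved nothing beyond the scatter. I therefore expect no step beyond the scatter, a number 2.3 percentage points higher from compound 2 to compound 3 (within the scatter). Compound 3 is estimated at 15%, between 3% and 30%.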

Compound 3, a percentage reported as inhibition, at one concentration (the size of the read-out at that concentration, not a potency): 2.1%
The estimate for compound 3 lay 12.9 percentage points above the measured number; measured number outside the range, below it.
By their numbers in this assay, from the lowest: compound 3; then compounds 2 and 1 (each within the scatter of the next).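

In this assay, going by these compounds alone, placing (1-ethylpiperidin-4-yl)methyl instead of 1-isopropylpiperidin-4-yl on this oxygen gives a number 10.6 percentage points lower from compound 2 to compound 3 (beyond the scatter), the only step here from compound 2 to go beyond the scatter. The two groups hold the same atoms, joined differently, so this position is sensitive to more than atom content alone. Replacing piperidin-4-yl with the same group gives a number 18.5 percentage points lower from compound 1 to compound 3 (beyond the scatter), and nothing available explains either loss. On these data alone, it remains open whether the ethyl or the extra carbon linking the ring to oxygen matters more. A (1-isopropylpiperidin-4-yl)methyl group would help separate the two.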